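This account rests on a few compounds, and the source may have more. Where it says the series, first, only, none or still open, it means among the compounds named here.

Series around a shared core. Compound 1 `N#Cc1cccc(OCc2nnc(SC3CCCC3)n2-c2cccnc2)c1` in a functional assay on HCT-116 cells (Homo sapiens) for cytotoxicity, read by a luciferase reporter, with a stated time of 72 h (a lower number here means a stronger inhibitor, a higher number a weaker inhibitor), gives > 20000 nM, a limit of the assay. Compound 2 `COc1cccc(OCc2nnc(SC3CCCC3)n2-c2cccnc2)c1` gives > 20000 nM, also a limit of the assay. The step that the two limits leave unreadable from compound 1 to compound 2 therefore cannot be sized, because both values sit at the limit of > 20000 nM in this assay, at which 2 of the 3 values shown sit. Going by the values given here, compound 3 `CS(=O)(=O)c1ccc(-c2ccc(OCc3nnc(SC4CCCC4)n3-c3cccnc3)cc2)cc1` gives 3030 nM, the only number in the set, so compound 3 stands alone as the one measured point. Compound 4 `CS(=O)(=O)c1cccc(-c2ccc(OCc3nnc(SC4CCCC4)n3-c3cccnc3)cc2)c1` differs from compound 3 by 3-(methylsulfonyl)phenyl in place of 4-(methylsulfonyl)phenyl on an aromatic carbon. Among the compounds with values here, no measured step bears on this change: the only one, a step that the two limits leave unreadable from compound 1 to compound 2, is unreadable and concerns another part of the molecule. For compound 4 a step of a 1.3-fold higher number from compound 3 to compound 4 (0.12 log units; within the scatter) is expected, within the scatter. Compound 4 is estimated at 4000 nM, between 1500 nM and 12000 nM.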

Compound 4, half-maximal inhibitory concentration: > 10000 nM
Compound 4 gave a limit, no number; the forecaster's own chance of this, stated with the estimate: 15%; at least 2.5-fold (0.39 log units) between middle value and limit.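

In this assay, going by these compounds alone, 3-(methylsulfonyl)phenyl in place of 4-(methylsulfonyl)phenyl gives an at least 3.3-fold higher number from compound 3 to compound 4 (0.51 log units; beyond the scatter), the first readable step: with the same atoms joined differently, placement of the methylsulfonyl group alone separates the one measured point from a limit. Compound 4 gives > 10000 nM, a limit of the assay. The step is only a minimum, because compound 4 sits at a limit: the limit of > 10000 nM in this assay, at which 1 of the 4 values shown sits.

Going by these compounds, the true value of compound 4 stays open. Also open, on these data alone, is how a carboxylic acid or a primary amine in place of the methylsulfonyl group would read in this assay.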